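The source may hold more compounds than are shown below. What is called first, only, known or untested is meant among the compounds shown, and "the series" means these compounds.

Measured in a functional assay on HCT-116 cells (Homo sapiens) for inhibition, read by MTT assay, with a stated time of 48 h; a lower number here means a stronger inhibitor, a higher number a weaker inhibitor:
- Compound 1 `COc1cc(-c2nnc(SCc3ccccc3)n2-c2ccc(N(C)C)cc2)cc(OC)c1OC`: 54000 nM
- Compound 2 `COc1cc(-c2nnc(SCC(=O)c3ccc4ccccc4c3)n2-c2ccc(N(C)C)cc2)cc(OC)c1OC`: 54500 nM

Compound 2 stands level with compound 1 within the scatter, so neither can be ranked above the other. Compound 3 `COc1cc(-c2nnc(SCC(=O)C3CC3)n2-c2ccc(N(C)C)cc2)cc(OC)c1OC` carries cyclopropyl in place of naphthalen-2-yl on a carbonyl carbon. Among the compounds with values here, only one measured step bears on this change. That step, a 1.0-fold higher number from compound 1 to compound 2 (0.00 log units; within the scatter), put (naphthalen-2-yl)carbonyl in place of phenyl on a saturated chain carbon bound to a sulfur, and it stayed within the scatter. Within the data shown here, no measured compound carries cyclopropyl, so this evidence is thin. Even so, no step beyond the scatter is expected in this assay, in either direction. The expected change is a 1.0-fold higher number from compound 2 to compound 3 (0.00 log units; within the scatter). The estimate for compound 3 is 55000 nM, with an expected range of 25000 nM to 110000 nM.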

Compound 3, half-maximal inhibitory concentration: > 60000 nM
Compound 3 ended at the assay's limit; the forecaster's own chance of this, stated with the estimate: 10%; middle value at least 1.0-fold (0.03 log units) away from the limit.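

In this assay compound 3 gives > 60000 nM as a limit of the assay and not a number: the limit of > 60000 nM in this assay, at which 1 of the 3 values shown sits. Cyclopropyl in place of naphthalen-2-yl on a carbonyl carbon reads as an at least 1.1-fold higher number from compound 2 to compound 3 (0.04 log units; that floor lies within the scatter) and cyclopropylcarbonyl in place of phenyl reads as an at least 1.1-fold higher number from compound 1 to compound 3 (0.04 log units; that floor lies within the scatter) with both figures being floors, so the true size of either step stays unknown. The earlier pair did not vary the group on the carbonyl carbon, and cutting it from 10 heavy atoms to 3 brings no lower number here.

As far as these compounds go, the true value of compound 3 remains open. So does whether an amine or a carboxylic acid on this carbonyl carbon would bring a lower number in this assay at all.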